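The compounds below may be only part of what the source reports. "The series", "measured", "known", "first", "only" and "open" are said of these compounds alone.

Measured compounds in an ADME assay on NCM460 cells (Homo sapiens) for cytotoxicity, read by MTT assay, with a stated time of 72 h, in the presence of a further agent that is not named here; on this read-out higher numbers stand for an effect only at larger amounts of compound and lower numbers for an effect already at smaller amounts:
compound 1 `O=C(Nc1cc(Cl)nc(Cl)c1)Nc1cc2ccccn2n1`: 10200 nM
compound 2 `Cc1cc(NC(=O)Nc2cc(Cl)nc(Cl)c2)n(C)n1`: 134000 nM
compound 3 `O=C(Nc1cc(Cl)nc(Cl)c1)Nc1cc(Cl)nc(Cl)c1`: 9440 nM

Compound 3 holds the lowest of the three numbers in this assay. The number for compound 1 sits within the scatter of that for compound 3, so the two are not separated. Compound 2 stands beyond the scatter, with a clearly higher number than compound 3.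

Compound 4 `CCOc1cc(NC(=O)Nc2cc(Cl)nc(Cl)c2)cc(Cl)n1` differs from compound 3 by ethoxy in place of chloro on an aromatic carbon. Within the data shown here, no measured pair in this set shows that change, so nothing here indicates its direction. The step from compound 3 to compound 4 in this assay is expected to be small, a 1.3-fold higher number from compound 3 to compound 4 (0.10 log units; within the scatter), not clearly beyond the scatter in either direction. Compound 4 is therefore estimated at 12000 nM, in a range from 4000 nM to 40000 nM.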

Compound 4, half-maximal effective concentration: 25300 nM
For compound 4 the middle estimate is 2.1-fold (0.32 log units) below the measured one, and the stated range covers the measured number.
By their numbers in this assay, from the lowest: compounds 3 and 1 (each within the scatter of the next); then compound 4; then compound 2.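

In this assay, among these compounds, ethoxy in place of chloro next to the ring nitrogen gives a 2.7-fold higher number from compound 3 to compound 4 (0.43 log units; beyond the scatter) as the first single-place step. This position on the shared core therefore registers in this read-out, and the change moves the number upward. Nothing available bears on the reason for this shift.

A single replacement leaves open whether methoxy, an amine or a longer alkoxy chain at this position would move the number further. On these data alone, whether the chloro groups elsewhere on the shared core respond in the same way also remains open.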